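Alkoxy for ethyl on the aryl ether series

The compounds below may be only part of what the source reports. "The series", "measured", "known", "first", "only" and "open" are said of these compounds alone.

Measured so far:
compound 1, `CCc1ccccc1OC(C)C1=NCCN1`: 100 nM
compound 2, `CCOc1ccccc1OC(C)C1=NCCN1`: 10000 nM

In a functional assay on CHO cells for agonist activity at Alpha-2C adrenergic receptor (Homo sapiens) (a higher number here means that more compound is needed for the effect, a lower number that less compound is needed), compound 1 gives 100 nM, the lowest of the two numbers at hand. Within the data shown here, compound 2 stands at 10000 nM, and the only single-point step available is a 100-fold higher number from compound 1 to compound 2 (2.00 log units; beyond the scatter). Among the measured compounds shown here, no other pair bears on the question.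

Compound 3, `CC(Oc1ccccc1OC1CC1)C1=NCCN1`, has not been measured in this assay. Against compound 1 the change is cyclopropyloxy in place of ethyl on an aromatic carbon. Like compound 2 it carries an ether oxygen on that aromatic carbon in place of the directly bound ethyl, so the measured step from compound 1 to compound 2 is the nearest precedent. For the measured compounds named here, whether the three-membered ring behaves as the ethyl of an ethoxy does cannot be read from the data; the expectation rests on the one step alone.

Compound 3 is therefore expected to give a markedly higher number, estimated as a 50-fold higher number from compound 1 to compound 3 (1.70 log units; beyond the scatter). The estimate for compound 3 in this assay is 5000 nM, with a range from 1000 nM to 30000 nM.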

Compound 3, half-maximal effective concentration: 47.9 nM
The estimate for compound 3 lay 100-fold (2.02 log units) above the measured number; measured number outside the range, below it.
By their numbers in this assay, from the lowest: compound 3; then compound 1; then compound 2.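

In this assay the ether oxygen on the aromatic carbon does not by itself set the number high: cyclopropyloxy in place of ethyl gives a 2.1-fold lower number from compound 1 to compound 3 (0.32 log units; beyond the scatter) and so keeps the series at the low end, a modest step. The group on the oxygen decides the outcome within this pair of ethers, with cyclopropyl in place of ethyl on that oxygen giving a 210-fold lower number from compound 2 to compound 3 (2.32 log units; beyond the scatter) in this assay while everything else in the two structures stays the same. Compound 3 therefore holds the lowest number of the three, with its steps to compound 1 and compound 2 both beyond the scatter, and at this position the presence of an oxygen says little until its substituent is known.

Going by these compounds, whether the low number belongs to the three-membered ring alone, or also appears with methoxy, isopropoxy, cyclobutyloxy or a longer chain on the oxygen, remains open, as does the result for a cyclopropyl bound directly to the aromatic carbon. No measurement at hand accounts for the gap between the two ethers.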